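The source may hold more compounds than are shown below. What is called first, only, known or untested is meant among the compounds shown, and "the series" means these compounds.

Measured so far in a functional assay on MDA-MB-231 cells (Homo sapiens) for inhibition, read by sulforhodamine B assay (on this read-out higher numbers stand for weaker inhibition and lower numbers for stronger inhibition), with these results:

- Compound 1 `COC(=O)CC/C(C)=C/Cc1c(OC)c(C)c2c(c1OCC#CCN1CCN(C(c3ccc(F)cc3)c3ccc(F)cc3)CC1)C(=O)OC2` gives > 50000 nM (a limit)
- Compound 2 `COC(=O)CC/C(C)=C/Cc1c(OC)c(C)c2c(c1OCC#CCN1CCN(c3ccc(O)cc3)CC1)C(=O)OC2` gives > 50000 nM (a limit)
- Compound 3 `COC(=O)CC/C(C)=C/Cc1c(OC)c(C)c2c(c1OCC#CCN1CCC(C(=O)OC)CC1)C(=O)OC2` gives > 50000 nM (a limit)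

For the measured compounds named here, the series so far offers only the limit of > 50000 nM in this assay, at which 3 of the 3 values shown sit, and no numeric value. Compound 2 stands with the other two compounds at that limit, so it gives no number to start from. Going by the values given here, no two measured compounds differ in one place, so no measured step is available to guide the next reading.

Compound 4 `COC(=O)CC/C(C)=C/Cc1c(OC)c(C)c2c(c1OCC#CCN1CCN(c3ccc(C)cc3)CC1)C(=O)OC2` awaits measurement. It carries methyl in place of hydroxy on an aromatic carbon, para to a large group, so that 4-hydroxyphenyl becomes 4-methylphenyl (methyl in place of hydroxy on an aromatic carbon).

In this assay no step beyond the scatter is expected, and no direction can be assigned from a limit. For compound 2 the limit of > 50000 nM is the ground of this expectation. The estimated step of a number no higher from compound 2 to compound 4 (the limit leaves the size open) is expected to stay within the usual scatter. Compound 4 is estimated at 50000 nM with an expected range from 15000 nM to 100000 nM and the read-out is expected most likely to be a limit again.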

Compound 4, half-maximal inhibitory concentration: > 50000 nM
Compound 4 was reported as a limit; the forecaster's own chance of this, stated with the estimate: 80%; the middle value lies on the limit itself.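

In this assay compound 2 and compound 4 are both reported as limits, so the change from 4-hydroxyphenyl to 4-methylphenyl gives no readable step. The compounds shown leave open how far any one of them differs from another on this read-out, with no numeric value to compare: the limit of > 50000 nM in this assay, at which 4 of the 4 values shown sit.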